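Pentyl ether of a saturated lactone: expected growth inhibition

A few compounds are considered here, and "the series" means these few. Any claim that something is new, unique, unknown or untested is made for them only; others in the source may bear on it.

Measured compounds in a functional assay on NCI/ADR-RES cells (Homo sapiens) for antiproliferative activity, read by sulforhodamine B assay, with a stated time of 48 h; a lower number here means a stronger inhibitor of growth, a higher number a weaker inhibitor of growth:
- compound 1 `COc1ccc2cc(CCCO)oc(=O)c2c1`: 28.1 ug/mL
- compound 2 `CCCCCOCCCc1cc2ccc(OC)cc2c(=O)o1`: 7.4 ug/mL
- compound 3 `COc1ccc2c(c1)C(=O)OC(CCCO)C2`: 93.3 ug/mL

Compound 3 has the highest number of the three; the difference between its core and the core of compound 1 is not broken down here. Compound 2 arises from compound 1 by the change (pentyl in place of hydrogen on an oxygen on a saturated carbon), and this step gives a 3.8-fold lower number from compound 1 to compound 2 (0.58 log units; beyond the scatter). Compound 4 `CCCCCOCCCC1Cc2ccc(OC)cc2C(=O)O1` arises from compound 3 by the same change, (pentyl in place of hydrogen on an oxygen on a saturated carbon), made at the same kind of place, so the two steps are of one kind. For the measured compounds named here, since compound 3 starts from 93.3 ug/mL, an estimate for compound 4 rests on applying a step like the one from compound 1 to compound 2 to it. On that basis compound 4 is expected to give 25 ug/mL, between 10 ug/mL and 60 ug/mL, meaning an expected step of a 3.7-fold lower number from compound 3 to compound 4 (0.57 log units; beyond the scatter).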

Compound 4, concentration for 50% growth inhibition: 42.3 ug/mL
Compound 4: middle estimate off by 1.7-fold (0.23 log units), on the low side; the measured number falls inside the stated range.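

In this assay, pentyl in place of hydrogen on the oxygen gives a 2.2-fold lower number from compound 3 to compound 4 (0.34 log units; beyond the scatter). The change lowers the number on both cores, and the two steps cannot be told apart: the same change on two cores in this assay, a 3.8-fold lower number (0.58 log units; beyond the scatter) from compound 1 to compound 2 and a 2.2-fold lower number (0.34 log units; beyond the scatter) from compound 3 to compound 4, 1.7-fold (0.24 log units) apart, within the scatter of two such steps. This shows that, for these two cores, the change carries over in direction and in a size that agrees within the scatter, but it does not show that it would do so on any other core, and it gives no reason for the step.

The compounds shown leave open whether the step is particular to pentyl. A methyl ether, a longer chain or an amine in its place might give a different step on either core.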